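From phenethyl to 2-methoxyethoxy on the shared core

This account rests on a few compounds, and the source may have more. Where it says the series, first, only, none or still open, it means among the compounds named here.

Values in an ADME assay on HEK293 cells (Homo sapiens) for cytotoxicity, with a stated time of 6 h (a higher number here means that more compound is tolerated, a lower number that less compound is tolerated), are these:
Compound 1 (`CCCCNc1nc(N)nc2cccc(Cl)c12`) gives 100 nM
Compound 2 (`CCCCNc1nc(N)nc2cccc(OC)c12`) gives the limit > 25000 nM
Compound 3 (`CCCCNc1nc(N)nc2cccc(CCc3ccccc3)c12`) gives the limit > 25000 nM

Compound 3 stands at the limit of > 25000 nM in this assay, at which 2 of the 3 values shown sit, and has no number of its own. Compound 4 (`CCCCNc1nc(N)nc2cccc(OCCOC)c12`) differs from it thus: 2-methoxyethoxy in place of phenethyl on an aromatic carbon. For the measured compounds named here, two measured steps bear on this, and both leave the chloro of compound 1. Both are large: an at least 250-fold higher number from compound 1 to compound 2 (2.39 log units; beyond the scatter) and an at least 250-fold higher number from compound 1 to compound 3 (2.39 log units; beyond the scatter). The remaining comparison is a step that the two limits leave unreadable from compound 2 to compound 3. Compound 4 also lacks the chloro. In this assay the expected result is therefore no step beyond the scatter, the estimated step being a number no higher from compound 3 to compound 4 (the limit leaves the size open). For compound 4 the estimate is 25000 nM with an expected range from 10000 nM to 50000 nM.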

Compound 4, half-maximal cytotoxic concentration: 10000 nM
Beside the measured number, compound 4's estimate is 2.5-fold (0.40 log units) above it; the measured number falls inside the stated range.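

In this assay, for the compounds shown here, compound 4 is the first compound without the chloro to give a number rather than a limit, so losing the chloro does not by itself carry a compound to the limit. Lengthening methoxy to 2-methoxyethoxy brings an at least 2.5-fold lower number from compound 2 to compound 4 (0.39 log units; beyond the scatter), the change from phenethyl brings an at least 2.5-fold lower number from compound 3 to compound 4 (0.39 log units; beyond the scatter), and a 100-fold higher number from compound 1 to compound 4 (2.00 log units; beyond the scatter) remains. The first two steps start from a limit: the limit of > 25000 nM in this assay, at which 2 of the 4 values shown sit.

Going by these compounds, it stays open how a longer chain on the oxygen, or an amine at the end of it, would read. On these data alone, whether bromo in this place would fall near the chloro is also open.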